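Aryloxy variation in a pyrrolidine acid series of agonists

The compounds below may be only part of what the source reports. "The series", "measured", "known", "first", "only" and "open" are said of these compounds alone.

Compound 1 `Cc1ccccc1Oc1ccc(N2CCC[C@H]2CC(=O)O)cc1`: 74 nM
Compound 2 `O=C(O)C[C@@H]1CCCN1c1ccc(Oc2ccc(Cl)cc2Cl)cc1`: 360 nM
Compound 3 `O=C(O)C[C@@H]1CCCN1c1ccc(Oc2ccccc2F)cc1`: 150 nM

Three compounds share a core and differ only in the aromatic group carried on the oxygen. In a functional assay on cells for agonist activity at Free fatty acid receptor 1 (Homo sapiens), read by FLIPR and calcium flux, with a stated time of 100 s (a lower number here means that less compound is needed, a higher number that more compound is needed for the effect), compound 1 gives 74 nM, compound 2 gives 360 nM and compound 3 gives 150 nM. Compound 3 therefore stands second of the three: the step of a 2.0-fold higher number from compound 1 to compound 3 (0.31 log units; beyond the scatter) is beyond the scatter, as is the step of a 2.4-fold lower number from compound 2 to compound 3 (0.38 log units; beyond the scatter).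

Compound 4 `Cc1cccc(Oc2ccc(N3CCC[C@H]3CC(=O)O)cc2)c1` is the next member. Relative to compound 3 it carries 3-methylphenyl in place of 2-fluorophenyl on an oxygen on an aromatic ring. Within the data shown here, no measured step places a methyl at this position of the ring. The closest guide is a 2.0-fold higher number from compound 1 to compound 3 (0.31 log units; beyond the scatter), a modest step, which shows that a methyl on the ring on the oxygen gave a lower number than a fluoro in this assay; the step of a 4.9-fold higher number from compound 1 to compound 2 (0.69 log units; beyond the scatter) shows that a more heavily substituted ring raised the number. A methyl is kept in compound 4, so the expectation is a number near that of compound 1, with a modest lowering from compound 3 expected, as a 1.5-fold lower number from compound 3 to compound 4 (0.18 log units; within the scatter). Compound 4 is estimated at 100 nM in this assay, within a range from 40 nM to 250 nM.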

Compound 4, half-maximal effective concentration: 260 nM
The estimate for compound 4 lay 2.6-fold (0.41 log units) below the measured number; measured number outside the range, above it.
By their numbers in this assay, from the lowest: compound 1; then compounds 3, 4 and 2 (each within the scatter of the next, the first and the last beyond it).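

Compound 4 keeps a methyl on the ring on the oxygen, and 3-methylphenyl in place of 2-methylphenyl gives, in this assay, a 3.5-fold higher number from compound 1 to compound 4 (0.55 log units; beyond the scatter). Among these compounds, the low number of compound 1 therefore does not come with a methyl on this ring as such, but with the 2-methylphenyl group in particular, which the earlier compounds could not show because none of them carried the methyl anywhere else. The other two new steps, a 1.7-fold higher number from compound 3 to compound 4 (0.24 log units; within the scatter) and a 1.4-fold lower number from compound 2 to compound 4 (0.14 log units; within the scatter), both lie within the scatter, so 3-methylphenyl cannot be told apart from 2-fluorophenyl or from 2,4-dichlorophenyl here, and among these four compounds only the 2-methylphenyl group stands clear of the others.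

Nothing available accounts for the difference between the two methylphenyl groups. The compounds shown also leave open how an unsubstituted phenyl on the oxygen would compare, and whether an ethyl or a methoxy group in place of the methyl of compound 1 would keep its number.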